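A few compounds are considered here, and "the series" means these few. Any claim that something is new, unique, unknown or untested is made for them only; others in the source may bear on it.

Of the compounds shown here, two sharing one core have been tested in a functional assay on HeLa cells (Homo sapiens) for antiproliferative activity, read by CCK-8 assay, with a stated time of 72 h, tested at 2 uM; a higher number here means a stronger effect of the compound at the concentration tested, a lower number a weaker effect. Compound 1 `CCN(Cc1ccncc1)C(=S)SCc1ccc(C(=O)Nc2ccccc2N)cc1` gives 63.5% in this assay. Compound 2 `Nc1ccccc1NC(=O)c1ccc(CSC(=S)N2CCN(Cc3ccncc3)CC2)cc1` gives 59.5% in this assay, a number that differs from that of compound 1 by an amount within the usual scatter of repeated measurements, so the two cannot be told apart on these numbers alone.

Compound 3 `Nc1ccccc1NC(=O)c1ccc(CSC(=S)N2CCN(c3cccnc3)CC2)cc1` has not yet been measured. It differs from compound 2 in one place: pyridin-3-yl in place of (pyridin-4-yl)methyl on an amine nitrogen in a ring. Going by the values given here, no pair of measured compounds shows what such a change does in this assay, so there is no measured step to lean on.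

With that in mind, the step from compound 2 to compound 3 is expected to be a number 4.5 percentage points lower from compound 2 to compound 3 (within the scatter) in this assay, that is, no change beyond the scatter, though the uncertainty is wide. Compound 3 is therefore estimated to give about 55% in this assay, with a plausible range from 35% to 75%.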

Compound 3, a percentage reported as inhibition, at one concentration (the size of the read-out at that concentration, not a potency): 66.2%
The estimate for compound 3 lay 11.2 percentage points below the measured number, and the stated range covers the measured number.
By their numbers in this assay, from the lowest: compounds 2, 1 and 3 (each within the scatter of the next).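

In this assay, putting pyridin-3-yl in place of (pyridin-4-yl)methyl on the amine nitrogen in the ring gives a number 6.7 percentage points higher from compound 2 to compound 3 (within the scatter). Going by these compounds alone, this is the only measured step at this position, and it shows that this exchange leaves the read-out at a single concentration indistinguishable from no change: the pyridine ring can sit directly on the ring nitrogen, without the methyl link, and the number stays within the scatter of compound 2. No measurement is available that would explain this outcome or connect it to any property of the two groups.

The step also changes two things at once, the methyl link and the point at which the pyridine ring is attached, so the effect of each alone cannot be separated, and a read-out at one concentration does not show whether compound 2 and compound 3 have the same potency. As far as these compounds go, whether a plain phenyl ring, a pyridin-2-yl group or a longer chain such as 2-(pyridin-4-yl)ethyl would also keep the number in this range remains open.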